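Swapping cyclohexyl for a trifluoromethyl aromatic group

The source may hold more compounds than are shown below. What is called first, only, known or untested is meant among the compounds shown, and "the series" means these compounds.

Two compounds have been measured in a functional assay on KMS-11 cells (Homo sapiens) for antiproliferative activity, read by CellTiter-Glo, with a stated time of 72 h (a lower number here means a stronger inhibitor, a higher number a weaker inhibitor), so far
- compound 1 (`COc1ccc(C(=O)N(Cc2ccncc2)Cc2cccc(OCCc3cccc(C(F)(F)F)c3)c2)cc1`) gives 8900 nM
- compound 2 (`COc1ccc(C(=O)N(Cc2ccncc2)Cc2cccc(OCC3CCCCC3)c2)cc1`) gives 19700 nM

Compound 2 at 19700 nM holds the higher of the two numbers, making it the weaker of the pair. Compound 3 (`COc1ccc(C(=O)N(Cc2ccncc2)Cc2cccc(OCc3ccc(C(F)(F)F)cc3)c2)cc1`) awaits measurement in this assay and differs from compound 2 (4-(trifluoromethyl)phenyl in place of cyclohexyl on a saturated chain carbon bound to an oxygen on an aromatic ring) on that saturated chain carbon. Going by the values given here, the one measured step that bears on this is modest but beyond the scatter (a 2.2-fold higher number from compound 1 to compound 2 (0.35 log units; beyond the scatter)) and put cyclohexyl in place of 3-(trifluoromethyl)benzyl. Compound 3 only loosely reverses that change, so a modest move to a lower number is expected. The expected size is an estimated (a 2.0-fold lower number from compound 2 to compound 3 (0.29 log units; within the scatter)) shift. Compound 3 is estimated at 10000 nM with an expected range of 4000 nM to 22000 nM in this measurement.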

Compound 3, half-maximal inhibitory concentration: 14300 nM
Estimate against measurement, compound 3: 1.4-fold (0.16 log units) below, and the stated range covers the measured number.
By their numbers in this assay, from the lowest: compounds 1, 3 and 2 (each within the scatter of the next, the first and the last beyond it).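

On this saturated chain carbon, swapping the non-aromatic cyclohexyl for the aromatic 4-(trifluoromethyl)phenyl gives no change that can be told from assay noise, with a 1.4-fold lower number from compound 2 to compound 3 (0.14 log units; within the scatter). Going by these compounds alone, the 3-(trifluoromethyl)benzyl group cannot be separated from 4-(trifluoromethyl)phenyl either, with a 1.6-fold higher number from compound 1 to compound 3 (0.21 log units; within the scatter), so the new group falls within the scatter of both groups in the one earlier step that exceeded it. Nothing available explains these numbers. From the compounds shown here alone, whether an amine or a carboxylic acid at this place would give a change beyond the scatter remains open. Going by these compounds, a longer chain carrying the 4-(trifluoromethyl)phenyl ring is an equally open case.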